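Shortening the hydroxamic chain of compound 2

The compounds below may be only part of what the source reports. "The series", "measured", "known", "first", "only" and "open" are said of these compounds alone.

Compound 1 `CC(C)c1cc(C(=O)Nc2cccc(NC(=O)CCCCCCC(=O)NO)c2)c(O)cc1O` gives > 10000 nM as a limit
Compound 2 `CC(C)c1cc(C(=O)N(C)c2ccc(NC(=O)CCCCCCCCC(=O)NO)cc2)c(O)cc1O` gives 210 nM as a number

For the measured compounds named here, in a functional assay on NCI-H1975 cells (Homo sapiens) for inhibition, read by sulforhodamine B assay, with a stated time of 48 h (on this read-out lower numbers stand for stronger inhibition of growth and higher numbers for weaker inhibition of growth), compound 2 gives 210 nM as the only true number so far. Compound 1 reads > 10000 nM in this assay and that is a limit, not a number.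

Compound 3 `CC(C)c1cc(C(=O)N(C)c2ccc(NC(=O)CCCCCC(=O)NO)cc2)c(O)cc1O` alters compound 2 in one place, and hydroxycarbamoyl in place of 3-(hydroxycarbamoyl)propyl on a saturated chain carbon, five bonds along the chain from a carbonyl carbon sets out the count of that change: hydroxycarbamoyl in place of 3-(hydroxycarbamoyl)propyl on a saturated chain carbon, five bonds along the chain from a carbonyl carbon. The chain ending in hydroxycarbamoyl thus becomes shorter. Going by the values given here, no measured pair shows this change alone, so any forecast is loose. Starting from compound 2 at 210 nM as the sole anchor, weaker growth inhibition is expected, by more than the usual scatter. The expected change is a 3.3-fold higher number from compound 2 to compound 3 (0.52 log units; beyond the scatter) in this assay overall. Compound 3 is estimated at 700 nM with an expected range from 150 nM to 3500 nM once measured.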

Compound 3, concentration for 50% growth inhibition: 690 nM
Compound 3: the middle estimate sits 1.0-fold (0.01 log units) above what was measured, and the stated range covers the measured number.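

For the compounds shown here, this is the first pair that differs in one place only, so the length of the chain ending in hydroxycarbamoyl can now be judged on its own. In this assay, putting hydroxycarbamoyl in place of 3-(hydroxycarbamoyl)propyl, on a saturated chain carbon five bonds along the chain from a carbonyl carbon, gives a 3.3-fold higher number from compound 2 to compound 3 (0.52 log units; beyond the scatter). Growth inhibition therefore responds to the length of this chain, yet it weakens rather than disappears, since the shorter compound 3 still gives a true number of 690 nM.

Going by these compounds, two chain lengths make a single step rather than a trend, so it remains open how a longer chain, or a carboxylic acid in place of the hydroxamic acid end, would read in this assay. Nothing among the data shown explains why the shorter chain reads weaker.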